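A few compounds are considered here, and "the series" means these few. Any claim that something is new, unique, unknown or untested is made for them only; others in the source may bear on it.

Three compounds share a common core, and each has been run in a physicochemical assay for lipophilicity, read by HPLC, using the shake flask method; a lower number here means a more polar compound, a higher number a more lipophilic compound. Compound 1 `CC(C)C/C(=N\C#N)N(C)Cc1ccc(Cl)nc1` gives 1.75. Compound 2 `C/C(=N\C#N)NCc1ccc(Cl)nc1` gives 1.07, and compound 3 `C=CCN(Cc1ccc(Cl)nc1)/C(C)=N/C#N` gives 1.56. Compound 1 sits at the top of these numbers, though its gap to compound 3 is within the scatter; only compound 2 stands clearly lower. For the measured compounds named here, the single measured step, a number 0.49 log units higher from compound 2 to compound 3 (beyond the scatter), shows a larger group on the amine nitrogen going with a higher number in that pair. Compound 4 `CC(C)/C(=N\C#N)N(C)Cc1ccc(Cl)nc1` differs from compound 1 by isopropyl in place of isobutyl on a carbon with a double bond to nitrogen. Going by the values given here, no measured step matches this change exactly, but the allyl step points to a modest fall when a group shrinks. Compound 4 is therefore expected to give 1.3, within 1 to 1.6. The expected step is a number 0.45 log units lower from compound 1 to compound 4 (beyond the scatter).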

Compound 4, partition coefficient: 1.39
Beside the measured number, compound 4's estimate is 0.09 log units below it; measured number inside the range.
By their numbers in this assay, from the lowest: compound 2; then compounds 4, 3 and 1 (each within the scatter of the next, the first and the last beyond it).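

In this assay, isopropyl in place of isobutyl on a carbon with a double bond to nitrogen gives a number 0.36 log units lower from compound 1 to compound 4 (beyond the scatter). For the compounds shown here, this is the first measured step at this position, showing that a change to this chain alone can move the number beyond the scatter; the earlier step was on an amine nitrogen. No measurement here explains the drop. From the compounds shown here alone, a longer chain such as hexyl, or a carboxylic acid or an amine at this position, remains open. So does whether the direction of this step holds beyond this one pair.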